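A few compounds are considered here, and "the series" means these few. Any claim that something is new, unique, unknown or untested is made for them only; others in the source may bear on it.

Compound 1 `CNC(=O)c1cc(C(=O)NC2CCC2)cn(Cc2ccccc2)c1=O` — in a physicochemical assay for solubility, read by HPLC, in simulated intestinal fluid, with a stated time of 16 h, tested at 125 ug/mL (on this read-out higher numbers stand for higher solubility and lower numbers for lower solubility), compound 1 gives 24 ug/mL
Compound 2 `CNC(=O)c1cc(C(=O)NC2CC2)cn(Cc2cccc3[nH]ccc23)c1=O` — in this assay compound 2 gives 17 ug/mL

Of the compounds shown here, two have been measured so far, and both sit close together. Compound 2 holds the lower of the two numbers, but its nearest neighbour, compound 1, differs from it by a gap that lies within the usual scatter of this measurement, so the two readings cannot be told apart with confidence, and neither compound can be called the more or less soluble one.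

Compound 3 `CNC(=O)c1cc(C(=O)NC2CC2)cn(Cc2cccc3c2CCN3)c1=O` has not yet been measured. It differs from compound 2 in one place: 2,3-dihydro-1H-indol-4-yl in place of 1H-indol-4-yl on a saturated chain carbon bound to an aromatic nitrogen The two compounds share the same core and the same remaining substituents, so whatever compound 3 shows will come from this change alone.

Within the data shown here, no step between two measured compounds is available to anchor an expectation, and the change is small in atom count. On that basis the step from compound 2 to compound 3 in this assay is expected to be modest, a 1.5-fold higher number from compound 2 to compound 3 (0.17 log units; within the scatter), leaning slightly upward but possibly within the scatter. Compound 3 is therefore estimated at 25 ug/mL, with a range from 10 ug/mL to 60 ug/mL.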

Compound 3, solubility: 100 ug/mL
Compound 3: middle estimate off by 4.0-fold (0.60 log units), on the low side; measured number outside the range, above it.
By their numbers in this assay, from the lowest: compounds 2 and 1 (each within the scatter of the next); then compound 3.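

Moving from 1H-indol-4-yl to 2,3-dihydro-1H-indol-4-yl on a saturated chain carbon bound to an aromatic nitrogen gives, in this assay, a 5.9-fold higher number from compound 2 to compound 3 (0.77 log units; beyond the scatter), the first step in this series that clears the scatter. This shows that the read-out responds to a change at this position even though the leaving and entering groups have the same count of heavy atoms and differ in that the five-membered ring is aromatic in one and non-aromatic in the other, with a hydrogen-bond acceptor counted only on the entering group; compounds 1 and 2 could not show this, since they differ in more than one place and their values lie within the scatter of each other. Nothing measured here accounts for the size of this step.

From the compounds shown here alone, it remains open whether a similar step would appear with the core of compound 1, or whether it is tied to the rest of compound 3. Going by these compounds, it is also open how a simple amine or a carboxylic acid on the benzyl ring at this position would compare with 2,3-dihydro-1H-indol-4-yl in this assay.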